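Removing the Pentyl Chain from a Sulfonamide Core

The source may report more compounds than this note shows. Statements on the series, on what has been measured and on what is new or still open speak of the compounds shown alone.

Compound 1 `CCCCCc1ccc(NS(=O)(=O)c2ccc(N3CCNC3=O)cc2)cc1` carries a pentyl chain on the ring attached to the sulfonamide nitrogen. In a functional assay on MCF7 cells (Homo sapiens) for antiproliferative activity, read by sulforhodamine B assay, with a stated time of 48 h (on this read-out higher numbers stand for weaker inhibition and lower numbers for stronger inhibition), compound 1 gives only a limit, > 1000 nM, and not a measured number. Compound 2 `O=C1NCCN1c1ccc(S(=O)(=O)Nc2ccc(I)cc2)cc1` gives 600 nM and compound 3 `Cc1cccc(NS(=O)(=O)c2ccc(N3CCNC3=O)cc2)c1` gives 190 nM. Compound 4 `O=C1NCCN1c1ccc(S(=O)(=O)Nc2ccccc2)cc1` is not yet measured; it differs from compound 1 by hydrogen in place of pentyl on an aromatic carbon. Among the measured compounds shown here, two measured steps bear on this change. Replacing the pentyl by iodo gave an at least 1.6-fold lower number from compound 1 to compound 2 (0.22 log units; that floor lies within the scatter), a floor only because compound 1 sits at the limit of > 1000 nM in this assay, at which 1 of the 3 values shown sits, and moving on to the 3-methylphenyl gave a 3.2-fold lower number from compound 2 to compound 3 (0.50 log units; beyond the scatter). Both steps lowered the number once the pentyl chain was gone, so removing it entirely is expected to lower the number too, by an at least 2.0-fold lower number from compound 1 to compound 4 (0.30 log units; that floor lies within the scatter). Compound 4 is therefore estimated at 500 nM, within a range from 150 nM to 2000 nM.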

Compound 4, half-maximal inhibitory concentration: 470 nM
For compound 4 the middle estimate is 1.1-fold (0.03 log units) above the measured one; the range from low to high includes it.
By their numbers in this assay, from the lowest: compound 3; then compounds 4 and 2 (each within the scatter of the next). At a limit, above all of these: compound 1.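

In this assay, simply dropping the pentyl gives an at least 2.1-fold lower number from compound 1 to compound 4 (0.32 log units; beyond the scatter), a floor and not an exact size, since compound 1 gives only a limit: the limit of > 1000 nM in this assay, at which 1 of the 4 values shown sits. So the chain need not be swapped for another group for the number to fall, and hydrogen and iodo on this carbon cannot be told apart, with a 1.3-fold lower number from compound 2 to compound 4 (0.11 log units; within the scatter). Removing the methyl, by contrast, gives a 2.5-fold higher number from compound 3 to compound 4 (0.39 log units; beyond the scatter).

As far as these compounds go, whether a shorter chain such as ethyl, or an amine or a carboxylic acid on this carbon, would lower the number further stays open.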